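The source may report more compounds than this note shows. Statements on the series, on what has been measured and on what is new or still open speak of the compounds shown alone.

Measured so far:
compound 1 `CCN(CC)CCNC(=O)c1ccc(C(CC)(CC)c2ccc(OCS(=O)(=O)c3ccccc3)c(C)c2)n1CC` gives 6270 nM in a functional assay on BXPC-3 cells (Homo sapiens) for antiproliferative activity, read by MTT assay, with a stated time of 24 h; a lower number here means a stronger inhibitor, a higher number a weaker inhibitor;
compound 2 `CCn1c(C(=O)N[C@H](CO)C(C)C)ccc1C(CC)(CC)c1ccc(OCS(=O)(=O)c2ccccc2)c(C)c1` gives 7720 nM in this assay.

Compound 2 and compound 1 sit within the scatter of each other, so neither can be called the stronger inhibitor. Compound 3 `CCn1c(C(=O)NCC(=O)O)ccc1C(CC)(CC)c1ccc(OCS(=O)(=O)c2ccccc2)c(C)c1` is unmeasured; it carries carboxymethyl in place of 1-(hydroxymethyl)-2-methylpropyl on an amide-type nitrogen. Among the compounds with values here, the one measured step at the same amide-type nitrogen, a 1.2-fold higher number from compound 1 to compound 2 (0.09 log units; within the scatter), was within the scatter, so another swap of the group on that nitrogen is expected to move the number little. Compound 3 is therefore estimated at 8500 nM, with a range of 3000 nM to 25000 nM, a step of a 1.1-fold higher number from compound 2 to compound 3 (0.04 log units; within the scatter) that is expected to stay within the scatter.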

Compound 3, half-maximal inhibitory concentration: > 50000 nM
Compound 3 gave a limit, no number (the forecaster's own chance of this, stated with the estimate: 15%); at least 5.8-fold (0.76 log units) between middle value and limit.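

The group on this amide-type nitrogen matters more than the first swap suggested: carboxymethyl gives an at least 6.4-fold higher number from compound 2 to compound 3 (0.81 log units; beyond the scatter), and the comparison with the other measured compound gives an at least 7.9-fold higher number from compound 1 to compound 3 (0.90 log units; beyond the scatter). Both steps lie beyond the scatter. Compound 3 gives a limit, not a number: the limit of > 50000 nM in this assay, at which 1 of the 3 values shown sits.

The compounds shown leave open whether the carboxylic acid or the shorter chain accounts for this step. A methyl ester of compound 3, or a longer chain ending in a carboxylic acid, would separate the two.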